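A few compounds are considered here, and "the series" means these few. Any claim that something is new, unique, unknown or untested is made for them only; others in the source may bear on it.

Compound 1 `C1CCC(Nc2nc3nonc3nc2NC2CCCC2)C1` gives 45000 nM in an assay on mitochondria from L6 cells (Rattus norvegicus) for activation, with a stated time of 90 min; on this read-out lower numbers stand for an effect already at smaller amounts and higher numbers for an effect only at larger amounts of compound. Compound 2 `Fc1ccccc1Nc1nc2nonc2nc1NC1CCCCC1` gives 13400 nM in this assay, the lower of the two numbers, and its gap to compound 1 lies beyond the usual scatter. Compound 3 `Fc1ccc(Nc2nc3nonc3nc2Nc2ccccc2F)c(F)c1` differs from compound 2 in one place: 2,4-difluorophenyl in place of cyclohexyl on a nitrogen on an aromatic ring. Among the compounds with values here, with no measured pair differing in just one place, the direction of this change is uncertain; the expected step is a 2.7-fold lower number from compound 2 to compound 3 (0.43 log units; beyond the scatter), a modest lowering rather than none. Compound 3 is therefore estimated at 5000 nM, within a range from 1500 nM to 20000 nM.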

Compound 3, half-maximal effective concentration: 300 nM
Beside the measured number, compound 3's estimate is 17-fold (1.22 log units) above it, outside the stated range (below it).
By their numbers in this assay, from the lowest: compound 3; then compound 2; then compound 1.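

In this assay, putting 2,4-difluorophenyl in place of cyclohexyl gives a 45-fold lower number from compound 2 to compound 3 (1.65 log units; beyond the scatter) and shows, through the first pair differing in one place, that this nitrogen's group strongly affects the number. The aromatic ring and the two fluorine atoms enter together, so this single step cannot separate their contributions. Nothing given here explains the size of the step. As far as these compounds go, whether plain phenyl would give a similar step remains open. So does the outcome with an amine or a carboxylic acid on the ring.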